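A few compounds are considered here, and "the series" means these few. Any claim that something is new, unique, unknown or untested is made for them only; others in the source may bear on it.

Measured compounds:
- Compound 1 `O=C1C=C(Nc2cccc(F)c2)C(=O)c2c1nc1n2[C@H]2OC[C@@H](O)[C@H]2OC1` gives 5500 nM.
- Compound 2 `O=C1C(Nc2ccc(C(F)(F)F)cc2)=CC(=O)c2c1nc1n2[C@H]2OC[C@@H](O)[C@H]2OC1` gives only a limit of the assay, > 4000 nM.
- Compound 3 `COc1ccc(NC2=CC(=O)c3c(nc4n3[C@H]3OC[C@@H](O)[C@H]3OC4)C2=O)cc1` gives 4470 nM.

In a functional assay on MCF7 cells (Homo sapiens) for inhibition, read by sulforhodamine B assay (a lower number here means a stronger inhibitor, a higher number a weaker inhibitor), compound 1 stands level with compound 3, the two numbers lying within the scatter of repeated measurements. The step that the limit leaves unreadable from compound 2 to compound 3 cannot be read, because the limit of > 4000 nM in this assay, at which 1 of the 3 values shown sits, hides the size of any change. Compound 4 `Cc1ccc(NC2=CC(=O)c3nc4n(c3C2=O)[C@H]2OC[C@@H](O)[C@H]2OC4)cc1` differs from compound 1 by 4-methylphenyl in place of 3-fluorophenyl on an amine nitrogen. Within the data shown here, no measured step follows this same change with a readable size, so there is no ground to expect a move beyond the scatter in this assay in either direction. Compound 4 is therefore estimated at 5000 nM, between 1800 nM and 15000 nM, an expected step of a 1.1-fold lower number from compound 1 to compound 4 (0.04 log units; within the scatter).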

Compound 4, half-maximal inhibitory concentration: 1660 nM
Estimate against measurement, compound 4: 3.0-fold (0.48 log units) above; the measured number lies below the stated range.
By their numbers in this assay, from the lowest: compound 4; then compounds 3 and 1 (each within the scatter of the next).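

In this assay, 4-methylphenyl in place of 3-fluorophenyl on the amine nitrogen gives a 3.3-fold lower number from compound 1 to compound 4 (0.52 log units; beyond the scatter). Among these compounds, this is the first readable step at this position, and it shows that the group on this nitrogen can change the number beyond the scatter. Compound 2 still gives only a limit, so any step involving it cannot be read: the limit of > 4000 nM in this assay, at which 1 of the 4 values shown sits.

This single change swaps the substituent and its place on the ring together, so the two remain unseparated. From the compounds shown here alone, a 4-fluorophenyl or 3-methylphenyl group would tell them apart, and a longer chain such as 4-ethylphenyl remains open too.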